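The source may hold more compounds than are shown below. What is called first, only, known or untested is meant among the compounds shown, and "the series" means these compounds.

Of the compounds shown here, three have been measured in an assay on HEK293 cells for displacement of a labelled ligand from 5-hydroxytryptamine receptor 7 (Rattus norvegicus), with a stated time of 60 min (on this read-out lower numbers stand for stronger inhibition and higher numbers for weaker inhibition), all on one shared core and differing only in the substituent on the pendant phenyl ring. Compound 1 `FC(F)(F)c1ccc(-c2cn(Cc3ccccc3)c3c2CNCC3)cc1` gives 167 nM. Compound 2 `O=[N+]([O-])c1ccc(-c2cn(Cc3ccccc3)c3c2CNCC3)cc1` gives 450 nM. Compound 3 `Cc1ccc(-c2cn(Cc3ccccc3)c3c2CNCC3)cc1` gives 35 nM, the lowest of the three numbers; the nearest is compound 1 and the furthest compound 2. Of the measured steps, a 4.8-fold lower number from compound 1 to compound 3 (0.68 log units; beyond the scatter) and a 13-fold lower number from compound 2 to compound 3 (1.11 log units; beyond the scatter) both run toward compound 3, while a 2.7-fold higher number from compound 1 to compound 2 (0.43 log units; beyond the scatter) runs the other way.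

Compound 4 `COc1ccc(-c2cn(Cc3ccccc3)c3c2CNCC3)cc1` is not yet measured. Its difference from compound 3 is methoxy in place of methyl on an aromatic carbon, placed on an aromatic carbon of a six-membered aromatic ring of carbon only, para to a large group. For the measured compounds named here, no measured step exchanges methyl for methoxy; the three known steps all involve trifluoromethyl or nitro, and in each the methyl compound sits at the lowest number. The direction of the new step is therefore open. Since none of the steps in this assay bears on it directly, a step of modest size, or none beyond the scatter, is expected. For compound 4 the estimate in this assay is 60 nM, within 25 nM to 150 nM. This corresponds to an expected step of a 1.7-fold higher number from compound 3 to compound 4 (0.23 log units; within the scatter).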

Compound 4, inhibition constant: 290 nM
The estimate for compound 4 lay 4.8-fold (0.68 log units) below the measured number; the measured number lies above the stated range.
By their numbers in this assay, from the lowest: compound 3; then compounds 1, 4 and 2 (each within the scatter of the next, the first and the last beyond it).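

For the compounds shown here, at this place, on an aromatic carbon para to a large group, methyl is now the only one of the four groups that gives a low number in this assay: the step of an 8.3-fold higher number from compound 3 to compound 4 (0.92 log units; beyond the scatter) shows that methoxy does not act as a close stand-in for methyl, even though the exchange adds only one oxygen to the group. Compound 4 instead falls in with the other two, since a 1.6-fold lower number from compound 2 to compound 4 (0.19 log units; within the scatter) and a 1.7-fold higher number from compound 1 to compound 4 (0.24 log units; within the scatter) both lie within the scatter, so methoxy cannot be ordered against either group, although compound 1 and compound 2 remain beyond the scatter of each other. No measured data are at hand to explain the rise on going from methyl to methoxy.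

Still open, going by these compounds, is whether the low number belongs to methyl alone or extends to other groups at this place, such as ethyl, chlorine or a hydroxyl group. The compounds shown also leave open whether the gap between methyl and methoxy holds when the benzyl group on the shared core is replaced.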